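The compounds below may be only part of what the source reports. "The series", "measured", "known", "first", "only" and "open" are said of these compounds alone.

Measured compounds and their numbers in a functional assay on MV4-11 cells (Homo sapiens) for antiproliferative activity, with a stated time of 6 days, tested at 1.56 uM; a higher number here means a stronger effect of the compound at the concentration tested, a lower number a weaker effect:

compound 1, `CNC(=O)N1CCCc2ccc(NC(=O)c3cccc(-c4cnn(S(C)(=O)=O)c4)c3)cc21`: 1.6%
compound 2, `CNC(=O)N1CCCc2ccc(NC(=O)c3ccc(-c4cnn(C(C)=O)c4)cc3)cc21`: 23.9%

Compound 2 holds the highest of the two numbers in this assay. Its nearest neighbour is compound 1, whose number lies lower by a gap beyond the scatter, so the two compounds are genuinely told apart. The two measured compounds differ in more than one place, so no single-change step is available between them, and no cause for their gap is offered here.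

Compound 3, `CNC(=O)N1CCCc2ccc(NC(=O)c3ccc(-c4ccccn4)cc3)cc21`, is the next compound to be measured in this assay. It differs from compound 2 in one place:
pyridin-2-yl in place of 1-acetyl-1H-pyrazol-4-yl on an aromatic carbon

Among the measured compounds shown here, with no measured step of this kind to lean on, the size of the change going to compound 3 is open. The expectation is a small shift, if any, most likely downward from compound 2 and not clearly beyond the scatter: the step is estimated as a number 5.9 percentage points lower from compound 2 to compound 3 (within the scatter). For compound 3 the estimated value in this assay is 18%, with a range from 0% to 40%.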

Compound 3, a percentage reported as inhibition, at one concentration (the size of the read-out at that concentration, not a potency): 32%
Compound 3: middle estimate off by 14 percentage points, on the low side, and the stated range covers the measured number.
By their numbers in this assay, from the lowest: compound 1; then compounds 2 and 3 (each within the scatter of the next).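

In this assay, among the compounds shown here, pyridin-2-yl in place of 1-acetyl-1H-pyrazol-4-yl on an aromatic carbon, para to a large group, gives a number 8.1 percentage points higher from compound 2 to compound 3 (within the scatter), which is the only single-change step available so far. This position therefore accepts a six-membered aromatic ring with one hetero atom as well as a five-membered aromatic ring with two hetero atoms, and in this pair the read-out does not depend on keeping the acetyl group or its carbonyl, as compound 2 and compound 3 cannot be told apart. No measurement bearing on the reason for this tolerance is available here.

For the compounds shown here, this single step cannot separate the contribution of the ring size from that of the acetyl group, and a read-out at one concentration gives no potency for either compound. Still open, from the compounds shown here alone, is how the read-out responds at this position to an unsubstituted phenyl ring, or to a pyridin-2-yl ring carrying an amine or a carboxylic acid, and whether any such group would move it beyond the scatter.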